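This account rests on a few compounds, and the source may have more. Where it says the series, first, only, none or still open, it means among the compounds named here.

Among the compounds with values here, compound 1 `CCOC(=O)C(=O)Nc1cccccc1=O` gives 91% in a functional assay on the whole organism (strain Sprague-Dawley CD) for inhibition, with Rattus norvegicus as the target, read by paw edema, at a dose of 100 mg/kg by the oral route (a higher number here means a stronger effect of the compound at the dose given, a lower number a weaker effect), and stands highest of the two numbers so far; its nearest neighbour is compound 2 `CCOC(=O)C(=O)Nc1c(C)ccccc1=O`, which in this assay gives 37%, the one measured step being a number 54 percentage points lower from compound 1 to compound 2 (beyond the scatter). Compound 3 `CC(C)OC(=O)C(=O)Nc1cccccc1=O` differs from compound 1 by methyl in place of hydrogen on a saturated chain carbon bound to an oxygen next to a carbonyl group and a saturated chain carbon. The step from compound 1 to compound 2 sits on an aromatic carbon and does not bear on a change at the ester alkyl, so no guide exists for this place. The expected step is a number 11 percentage points lower from compound 1 to compound 3 (beyond the scatter), within the scatter. Compound 3 is estimated at 80%, between 55% and 95%.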

Compound 3, a percentage reported as inhibition, in the whole organism at one dose (the size of the read-out at that dose, not a potency): 72%
Compound 3: middle estimate off by 8 percentage points, on the high side; low and high end bracket the measured number.
By their numbers in this assay, from the lowest: compound 2; then compound 3; then compound 1.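

Ethoxy to isopropoxy, with the methyl added on the saturated chain carbon bound to an oxygen, gives a number 19 percentage points lower from compound 1 to compound 3 (beyond the scatter) in this assay. The ester alkyl is therefore a place where this change lowers the effect, yet compound 3 still gives 72% at the dose tested. Nothing at hand accounts for the drop.

As far as these compounds go, whether the drop follows the branching or the added carbon stays open, and a straight propyl ester would separate the two. So does the effect of a carboxylic acid in place of the ester.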